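A few compounds are considered here, and "the series" means these few. Any claim that something is new, unique, unknown or untested is made for them only; others in the source may bear on it.

Measured compounds in a functional assay on K562 cells (Homo sapiens) for inhibition, read by sulforhodamine B assay, with a stated time of 48 h; on this read-out lower numbers stand for stronger inhibition of growth and higher numbers for weaker inhibition of growth:
Compound 1 `CC1=CC[C@H](C(C)(C)NC(=S)N/N=C/c2ccccc2)CC1` gives 6300 nM.
Compound 2 `COc1ccc(/C=N/NC(=S)NC(C)(C)[C@H]2CC=C(C)CC2)cc1` gives 1500 nM.
Compound 3 `CC1=CC[C@H](C(C)(C)NC(=S)N/N=C/c2ccc(O)cc2)CC1` gives > 100000 nM; for compound 3 this is a limit of the assay, not a number (the limit of > 100000 nM in this assay, at which 1 of the 3 values shown sits).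

Compound 2 carries the lowest of the two numbers shown, with compound 1 nearest, and it is this compound from which the step to compound 4 is taken. Compound 4 `CC1=CC[C@H](C(C)(C)NC(=S)N/N=C/c2cccc(Cl)c2)CC1` differs from compound 2 in one place: 3-chlorophenyl in place of 4-methoxyphenyl on a carbon with a double bond to nitrogen. Within the data shown here, two measured steps touch the same carbon with a double bond to nitrogen: the step of a 4.2-fold lower number from compound 1 to compound 2 (0.62 log units; beyond the scatter), and the step of an at least 15-fold higher number from compound 1 to compound 3 (1.20 log units; beyond the scatter). Taking the methoxy off the ring would, on the first step alone, be expected to return the number toward that of compound 1; the entering chlorine has no measured counterpart in the series, so the effect of the 3-chlorophenyl itself cannot be gauged from these numbers. The expected step is therefore a modest rise, a 3.3-fold higher number from compound 2 to compound 4 (0.52 log units; beyond the scatter), with wide uncertainty. Compound 4 is expected to give about 5000 nM, between 1500 nM and 20000 nM.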

Compound 4, concentration for 50% growth inhibition: 5400 nM
The estimate for compound 4 lay 1.1-fold (0.03 log units) below the measured number, within the range that was stated.
By their numbers in this assay, from the lowest: compound 2; then compounds 4 and 1 (each within the scatter of the next). At a limit, above all of these: compound 3.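

In this assay, chlorine on the ring gives no separation from the plain phenyl compound: a 1.2-fold lower number from compound 1 to compound 4 (0.07 log units; within the scatter). The 3-chlorophenyl group does not match the 4-methoxyphenyl group, a 3.6-fold higher number from compound 2 to compound 4 (0.56 log units; beyond the scatter), so a substituent on this ring does not by itself lower the number, and among the compounds shown, only compound 2 stands apart on the low side. The step of an at least 18-fold lower number from compound 3 to compound 4 (1.26 log units; beyond the scatter) shows that the 4-hydroxyphenyl loss is not shared by the 3-chlorophenyl group, though compound 3 gives a limit of the assay, not a number: the limit of > 100000 nM in this assay, at which 1 of the 4 values shown sits.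

Still open, from the compounds shown here alone, is whether the low number of compound 2 belongs to the methoxy group itself or to its place on the ring, which a 3-methoxyphenyl or a 4-chlorophenyl group would separate. Also open, going by these compounds, is how an amine or a longer ether such as ethoxy would read on this ring.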